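The source may report more compounds than this note shows. Statements on the series, on what has been measured and on what is new or still open speak of the compounds shown alone.

Series notes. Compound 1 `COC(=O)C(=O)CNC1=CS(=O)(=O)O[C@@]12[C@@H](CO[Si](C)(C)C(C)(C)C)O[C@@H](n1cc(C)c(=O)n(C)c1=O)[C@@H]2O[Si](C)(C)C(C)(C)C` is assessed in a functional assay on HEL cells (Homo sapiens) for cytotoxicity, read by microscopy; on this read-out higher numbers stand for lower toxicity in this test and lower numbers for higher toxicity in this test. For compound 1 the value > 400000 nM is a limit of the assay and not a number (the limit of > 400000 nM in this assay, at which 1 of the 3 values shown sits). Compound 2 `COC(=O)CC(=O)NC1=CS(=O)(=O)O[C@@]12[C@@H](CO[Si](C)(C)C(C)(C)C)O[C@@H](n1cc(C)c(=O)n(C)c1=O)[C@@H]2O[Si](C)(C)C(C)(C)C` gives 400000 nM in this assay. For compound 3 `COC(=O)CNC1=CS(=O)(=O)O[C@@]12[C@@H](CO[Si](C)(C)C(C)(C)C)O[C@@H](n1cc(C)c(=O)n(C)c1=O)[C@@H]2O[Si](C)(C)C(C)(C)C` the value >= 400000 nM is likewise a limit of the assay (the limit of >= 400000 nM in this assay, at which 1 of the 3 values shown sits). Compound 1 thus stands at the ceiling of what this test reports, and the other two measured compounds sit at that same ceiling. The steps among the measured compounds, a number no higher from compound 1 to compound 2 (the limit leaves the size open), a step that the two limits leave unreadable from compound 1 to compound 3 and a number no lower from compound 2 to compound 3 (the limit leaves the size open), all leave their size unreadable. Compound 4 `COC(=O)CCNC1=CS(=O)(=O)O[C@@]12[C@@H](CO[Si](C)(C)C(C)(C)C)O[C@@H](n1cc(C)c(=O)n(C)c1=O)[C@@H]2O[Si](C)(C)C(C)(C)C` differs from compound 1 by (methoxycarbonyl)methyl in place of (methoxycarbonyl)carbonyl on a saturated chain carbon bound to an amine nitrogen. The measured changes nearest to this one rearrange the same methoxycarbonyl-bearing chain on the amine nitrogen and moved nothing that could be read. No step beyond the scatter is therefore expected in this assay. Compound 4 is expected to show a number no higher from compound 1 to compound 4 (the limit leaves the size open). The estimate for compound 4 is 400000 nM, within 200000 nM to 400000 nM, most likely reported once more as a limit.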

Compound 4, minimum cytotoxic concentration: >= 400000 nM
Compound 4: only a limit was reported; the forecaster's own chance of this, stated with the estimate: 85%; the middle value sits exactly at the limit.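

In this assay compound 4 gives >= 400000 nM, which is a limit of the assay and not a number. With the 2-(methoxycarbonyl)ethyl chain on the amine nitrogen, which lacks the second carbonyl of compound 1, the series gains one more compound at the ceiling: the limit of >= 400000 nM in this assay, at which 2 of the 4 values shown sit. The values give a number no lower from compound 2 to compound 4 (the limit leaves the size open). That step and the steps to compound 4 from compound 1 and compound 3 cannot be read in size, so this change shows no measurable difference in toxicity.

The compounds shown leave open whether any change on this chain brings a value down from the ceiling of this assay. A carboxylic acid in place of the methoxycarbonyl group, or a longer chain on the amine nitrogen, remains an open case.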